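Thioamide in place of dithiolethione on the shared core

The source may report more compounds than this note shows. Statements on the series, on what has been measured and on what is new or still open speak of the compounds shown alone.

Compound 1 `Cc1ccc(NC(=S)OCCNC(=O)C(C)(C)Oc2ccc(Cl)cc2)cc1` and compound 2 `O=C(Oc1ccc(-c2cc(=S)ss2)cc1)c1cccnc1` were both tested in an ADME assay on RAW264.7 cells (Mus musculus) for cytotoxicity, read by MTT assay, with a stated time of 48 h; a lower number here means a stronger inhibitor, a higher number a weaker inhibitor. Compound 1 reaches only the assay limit, > 800000 nM. Compound 2 likewise reaches only the assay limit, > 800000 nM. Compound 2 therefore stands at the limit of > 800000 nM in this assay, at which 2 of the 2 values shown sit, with no resolved number behind it. Compound 3 `NC(=S)c1ccc(OC(=O)c2cccnc2)cc1` differs from compound 2 by a group of 3 heavy atoms (1 carbon, 1 nitrogen, 1 sulfur; no ring) in place of a group of 6 heavy atoms (3 carbon, 3 sulfur; one five-membered aromatic ring with 2 hetero atoms), on an aromatic carbon. Among the compounds with values here, no step between measured compounds is available to calibrate this change. The expected step of a number no higher from compound 2 to compound 3 (the limit leaves the size open) is none beyond the usual scatter. Compound 3 is thus expected at 800000 nM, within 300000 nM to 2000000 nM, most probably reported again only as a limit.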

Compound 3, half-maximal inhibitory concentration: > 800000 nM
Compound 3 gave a limit, no number; the forecaster's own chance of this, stated with the estimate: 80%; the middle value lies on the limit itself.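

Within the data shown here, no step from compound 2 to compound 3 can be read, as both values are limits: the limit of > 800000 nM in this assay, at which 3 of the 3 values shown sit. The compounds shown leave open whether exchanging the group of 6 heavy atoms for the group of 3 heavy atoms changes cytotoxicity at all.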